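Swapping the aryl group on a urea in a kinase stabilisation series

This account rests on a few compounds, and the source may have more. Where it says the series, first, only, none or still open, it means among the compounds named here.

Compound 1 `CCOc1ccc(NC(=O)Nc2cc(C(C)(C)C)nn2-c2ccccc2)cc1` gives 0.8 degrees C in an assay on isolated protein for inhibition of serine/threonine-protein kinase 10 (Homo sapiens), read by thermal shift assay, tested at 10 uM (on this read-out lower numbers stand for weaker stabilisation of the target and higher numbers for stronger stabilisation of the target against heat), the highest of the three measured numbers. Going by the values given here, compound 2 `CC(C)(C)c1cc(NC(=O)Nc2cc(C(F)(F)F)cc(C(F)(F)F)c2)n(-c2ccc(F)cc2)n1` gives -0.6 degrees C and compound 3 `CC(C)(C)c1cc(NC(=O)Nc2cc(C(F)(F)F)cc(C(F)(F)F)c2)n(C(C)(C)C)n1` gives -0.7 degrees C; the only step between them, a number 0.10 degrees C lower from compound 2 to compound 3 (within the scatter), changes a group elsewhere and so says nothing direct about the present change. Compound 4 `CC(C)(C)c1cc(NC(=O)Nc2cc(F)cc(F)c2)n(-c2ccccc2)n1` differs from compound 1 by 3,5-difluorophenyl in place of 4-ethoxyphenyl on an amide-type nitrogen. Among the compounds with values here, no measured step covers this exchange; compounds 2 and 3, which carry another fluorine-bearing aryl on the same nitrogen, both sit beyond the scatter lower than compound 1. Compound 4 is therefore expected to fall slightly, by a number 0.70 degrees C lower from compound 1 to compound 4 (within the scatter), to an estimated 0.1 degrees C with a range of -0.9 degrees C to 1 degrees C.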

Compound 4, shift of the target's melting temperature: 2.5 degrees C
Estimate against measurement, compound 4: 2.4 degrees C below; the whole stated range lies below it.
By their numbers in this assay, from the lowest: compounds 3 and 2 (each within the scatter of the next); then compound 1; then compound 4.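

Going by these compounds alone, exchanging the aryl group on this amide-type nitrogen moves the stabilisation, with a number 1.7 degrees C higher from compound 1 to compound 4 (beyond the scatter) marking the only measured step at this position. The 4-ethoxyphenyl group is therefore not needed for stabilisation in this series, since 3,5-difluorophenyl, which has no hydrogen-bond acceptor, gives the higher number. Nothing available explains this rise. From the compounds shown here alone, it remains open whether both fluorines contribute, and how a plain phenyl or a phenyl carrying a nitrile or an amine would compare on the same nitrogen.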